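The source may report more compounds than this note shows. Statements on the series, on what has been measured and on what is new or still open speak of the compounds shown alone.

Working notes on the series.

Compound 1 `COCCN(C)S(=O)(=O)c1ccc(C)c(C#Cc2cc(Cl)ccc2OCC(=O)O)c1` gives 4.1 nM in an assay on CHO cells for displacement of a labelled ligand from prostaglandin D2 receptor 2 (Homo sapiens), read by scintillation counting (a higher number here means a weaker inhibitor, a lower number a stronger inhibitor), the lowest of the three numbers in hand and beyond the scatter from both others, so it stands as the strongest inhibitor of the set. Compound 3 `O=C(O)COc1ccc(Cl)cc1C#Cc1ccccc1Cl` gives 28 nM in this assay, and compound 2 `Cc1ncc(S(=O)(=O)N(C)C)cc1C#Cc1cc(Cl)ccc1OCC(=O)O` gives 41 nM. For the measured compounds named here, neither of these differs from compound 1 in one place only, so no single step is available to weigh the next change.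

Compound 4 `CCS(=O)(=O)c1ccc(C)c(C#Cc2cc(Cl)ccc2OCC(=O)O)c1` keeps the core of compound 1 and changes the group on the sulfonyl sulfur: ethyl in place of (2-methoxyethyl)(methyl)amino on a sulfonyl sulfur. Nothing in the measured compounds isolates this kind of change; compound 3, which carries no sulfonyl group at all, sits at 28 nM, which suggests the series tolerates variation at this position without collapsing.

A modest loss is expected, a 2.4-fold higher number from compound 1 to compound 4 (0.39 log units; beyond the scatter), of a size near the edge of the scatter. Compound 4 is estimated at 10 nM, with a range of 3 nM to 35 nM.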

Compound 4, inhibition constant: 8.6 nM
The estimate for compound 4 lay 1.2-fold (0.07 log units) above the measured number; the measured number falls inside the stated range.
By their numbers in this assay, from the lowest: compound 1; then compound 4; then compounds 3 and 2 (each within the scatter of the next).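

For the compounds shown here, the step on the sulfonyl sulfur is the first single change: ethyl in place of (2-methoxyethyl)(methyl)amino gives a 2.1-fold higher number from compound 1 to compound 4 (0.32 log units; beyond the scatter) in this assay. The loss is beyond the scatter but modest, so on this core the sulfonyl sulfur does not need the nitrogen, the ether oxygen or the longer group for compound 4 to hold at 8.6 nM. No measurement bears on why the number moves.

As far as these compounds go, the step changes the nitrogen, the ether oxygen and the chain length together, so their separate shares in the loss stay open. A 2-methoxyethyl chain joined directly to the sulfonyl sulfur, or a morpholine in the same place, would begin to pull these apart.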